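The source may hold more compounds than are shown below. What is called first, only, known or untested is meant among the compounds shown, and "the series" means these compounds.

Measured so far in a functional assay on CHO cells for antagonist activity at Orexin/Hypocretin receptor type 1 (Homo sapiens), read by FLIPR and calcium flux; a higher number here means a more potent compound, by a factor of ten per unit of this negative logarithm, a lower number a less potent compound:

compound 1 `Cc1ccnc(NC[C@@H]2CC3(CC3)CN2C(=O)c2nc(C)sc2-c2ccccc2)n1` gives 6.1
compound 2 `O=C(c1cc(Cl)ccc1-c1ncccn1)N1CC2(CC2)C[C@H]1CNc1ccc(C(F)(F)F)cn1` gives 8.1
compound 3 `Cc1ccc(-c2ncccn2)c(C(=O)N2CC3(CC3)C[C@H]2CNc2ccc(C(F)(F)F)cn2)n1` gives 8.4

Compound 1 stands lowest of the three numbers. Its nearest neighbour is compound 2, whose value lies well beyond the scatter above it, and compound 3 lies further still above compound 1, also beyond the scatter. Compounds 2 and 3 are within the scatter of each other, so no order is drawn between them.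

Compound 4 `Cc1nc(C(=O)N2CC3(CC3)C[C@H]2CNc2ccc(C(F)(F)F)cn2)c(-c2ccccc2)s1` is not yet measured in this assay. It differs from compound 1 in one place, with 5-(trifluoromethyl)pyridin-2-yl in place of 4-methylpyrimidin-2-yl on an amine nitrogen. Among the measured compounds shown here, the entering group is the same one carried on the amine nitrogen of compounds 2 and 3, though those two compounds also carry a different aryl amide, so no single-change step between measured compounds exists here.

For the step from compound 1 to compound 4 a rise in this assay beyond the scatter is expected, of roughly a number 1.50 log units higher from compound 1 to compound 4 (beyond the scatter), since compounds 2 and 3 with the entering group sit far above compound 1. Compound 4 is estimated at 7.6, with a range from 6.8 to 8.4.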

Compound 4, negative logarithm of the antagonist equilibrium constant: 8.4
For compound 4 the middle estimate is 0.80 log units below the measured one; the range from low to high includes it.
By their numbers in this assay, from the lowest: compound 1; then compounds 2, 3 and 4 (each within the scatter of the next).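

In this assay, 5-(trifluoromethyl)pyridin-2-yl in place of 4-methylpyrimidin-2-yl on an amine nitrogen gives a large rise (a number 2.30 log units higher from compound 1 to compound 4 (beyond the scatter)) with the rest of the structure unchanged. Among the compounds shown here, this is the first single-change reading at this position: the earlier compounds carrying the entering group also had a different aryl amide, so its contribution could not be separated from that of the amide. Nothing available here explains the size of this step.

Still open, going by these compounds, is which part of the entering group carries the rise, as the ring and the trifluoromethyl change together; a 5-methylpyridin-2-yl or a 5-chloropyridin-2-yl group would separate them. Also open, on these data alone, is whether a step of this size holds with the aryl amides of compounds 2 and 3.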